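Notes on the step from compound 2 to compound 3

The compounds below may be only part of what the source reports. "The series", "measured", "known", "first", "only" and "open" are said of these compounds alone.

Compound 1 (`C[C@H]1O[C@]1(C)C(=O)C[C@@H]1[C@@]2(C)[C@@H](O)CCC(C)(C)[C@]2(O)CC[C@@]1(C)O`) and compound 2 (`C[C@@H]1O[C@@]1(C)C(=O)C[C@@H]1[C@@]2(C)[C@@H](O)CCC(C)(C)[C@]2(O)CC[C@@]1(C)O`) were tested in a functional assay on HeLa cells (Homo sapiens) for cytotoxicity, read by MTT assay, with a stated time of 24 h; on this read-out higher numbers stand for weaker inhibition and lower numbers for stronger inhibition. Compound 1 gives > 10000 nM, which is a limit and not a number. Compound 2 gives > 10000 nM, also a limit, so its standing is known only as a limit and not as a number. This matches (the limit of > 10000 nM in this assay, at which 2 of the 2 values shown sit). For the measured compounds named here, the only measured step is a step that the two limits leave unreadable from compound 1 to compound 2, and it concerns (the fact that compounds 1 and 2 differ only in the configuration as drawn).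

Compound 3 (`C/C=C(\C)C(=O)C[C@@H]1[C@@]2(C)[C@@H](O)CCC(C)(C)[C@]2(O)CC[C@@]1(C)O`) keeps the shared core and changes the group on a carbonyl carbon: 1-methylprop-1-en-1-yl in place of 2,3-dimethyloxiran-2-yl on a carbonyl carbon. The measured step gives no size for this change, since it involves no change of group and cannot be read. Going by the values given here, no measured compound gives a number in this assay, so the data offer no sign of a gain. Compound 3 is therefore expected to show no step beyond the scatter, and no direction can be expected, with a limit again the likely result. The estimated step is a step that the limit leaves unreadable from compound 2 to compound 3. For compound 3 the estimated value is 15000 nM, with an expected range from 6000 nM to 40000 nM.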

Compound 3, half-maximal inhibitory concentration: > 10000 nM
Compound 3 ended at the assay's limit; the forecaster's own chance of this, stated with the estimate: 85%; the middle value is on the limit's open side.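

In this assay compound 3 gives > 10000 nM, a limit and not a number. The steps from compound 1 and from compound 2 to compound 3 cannot be read: the limit of > 10000 nM in this assay, at which 3 of the 3 values shown sit.

The compounds shown leave open whether 1-methylprop-1-en-1-yl or 2,3-dimethyloxiran-2-yl on a carbonyl carbon, or the configuration as drawn, makes any difference, as none of them gives a number.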